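Halogenated aryl piperazines on the aminothiophene ketone core

This account rests on a few compounds, and the source may have more. Where it says the series, first, only, none or still open, it means among the compounds named here.

Measured so far:
compound 1 `Nc1scc(CN2CCN(c3cc(Cl)cc(Cl)c3)CC2)c1C(=O)c1ccc(Cl)cc1` -1%
compound 2 `COc1ccc(N2CCN(Cc3csc(N)c3C(=O)c3ccc(Cl)cc3)CC2)cc1` -1.2%
compound 3 `Nc1scc(CN2CCN(c3c(F)cccc3F)CC2)c1C(=O)c1ccc(Cl)cc1` -12%

The three compounds share one core and differ only in the aryl group on an amine nitrogen in a ring. In a functional assay on CHO cells with adenosine receptor A1 (Homo sapiens) as the target, read by cAMP accumulation and immunoassay, with a stated time of 6 min, tested at 0.01 uM (a lower number here means a stronger effect, a higher number a weaker effect of the compound at the concentration tested), compound 2 gives -1.2%, the second highest of the three numbers; its nearest neighbour is compound 1, a number a number 0.2 percentage points lower from compound 1 to compound 2 (within the scatter), and the furthest is compound 3, a number a number 10.8 percentage points lower from compound 2 to compound 3 (beyond the scatter). Compound 1 and compound 2 thus lie together, while compound 3 sits apart by a modest margin, as a number 11 percentage points lower from compound 1 to compound 3 (beyond the scatter) also shows.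

Compound 4 `Nc1scc(CN2CCN(c3ccc(F)c(Cl)c3)CC2)c1C(=O)c1ccc(Cl)cc1` is not yet measured. Its change from compound 2 is 3-chloro-4-fluorophenyl in place of 4-methoxyphenyl on an amine nitrogen in a ring. For the measured compounds named here, the steps that bear on it are those replacing one aryl group by another on the same nitrogen: the exchange of 4-methoxyphenyl for 3,5-dichlorophenyl moved nothing beyond the scatter, whereas the exchange for 2,6-difluorophenyl gave a modest drop. Going by the values given here, no measured step involves 3-chloro-4-fluorophenyl, so the direction rests on these three compounds alone.

In this assay compound 4 is expected at about -3%, within -13% to 7%. The estimated step of a number 1.8 percentage points lower from compound 2 to compound 4 (within the scatter) is expected to stay within the scatter, since compound 1 with its two chlorines gave -1%.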

Compound 4, a percentage reported as activity, at one concentration (the size of the read-out at that concentration, not a potency): 4.2%
For compound 4 the middle estimate is 7.2 percentage points below the measured one, and the stated range covers the measured number.
By their numbers in this assay, from the lowest: compound 3; then compounds 2, 1 and 4 (each within the scatter of the next).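

In this assay, exchanging 4-methoxyphenyl for 3-chloro-4-fluorophenyl on the amine nitrogen in the ring removes the oxygen and its hydrogen-bond acceptor at an unchanged heavy-atom count, yet the result is a number 5.4 percentage points higher from compound 2 to compound 4 (within the scatter), so that acceptor is not needed to keep the read-out in this range. The mixed chlorine and fluorine pattern also sits with the chlorine-only aryl group, a number 5.2 percentage points higher from compound 1 to compound 4 (within the scatter), but is apart from the fluorine-only 2,6-difluorophenyl group, a number 16.2 percentage points higher from compound 3 to compound 4 (beyond the scatter), which shows that halogen substitution on this aryl group does not by itself place a compound with compound 3. Nothing available explains why compound 3 alone separates from the other three compounds.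

The compounds shown leave open whether a nitrile, an amine or a carboxylic acid on the aryl group, or a longer alkyl chain in place of it, would stay with compound 1, compound 2 and compound 4 or move towards compound 3. Each read-out also comes from a single concentration, so the potency of these compounds and the size of any real potency gap remain open.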